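The compounds below may be only part of what the source reports. "The series", "measured", "known", "first", "only" and "open" are said of these compounds alone.

Measured in a functional assay on DU-145 cells (Homo sapiens) for inhibition, read by trypan blue exclusion, with a stated time of 96 h; a higher number here means a weaker inhibitor of growth, a lower number a stronger inhibitor of growth:
- compound 1 `Cc1ccc(CS/C(=C/c2ccc(F)c([N+](=O)[O-])c2)C(=O)c2ccc(Cl)c([N+](=O)[O-])c2)cc1`: 1000 nM
- compound 2 `Cc1ccc(CS/C(=C/c2ccc(C(=O)O)cc2)C(=O)c2ccc(Cl)c([N+](=O)[O-])c2)cc1`: 10000 nM
- compound 3 `O=C(/C(=C\c1ccc(F)c([N+](=O)[O-])c1)SCc1ccc(Br)cc1)c1ccc(Cl)c([N+](=O)[O-])c1`: > 100000 nM (a limit of the assay)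

Of the two values that are actual numbers, compound 1 holds the lower. Compound 4 `Cc1ccc(CS/C(=C/c2ccc(F)c([N+](=O)[O-])c2)C(=O)c2ccc(C(=O)O)cc2)cc1`, not yet measured, has 4-carboxyphenyl in place of 4-chloro-3-nitrophenyl on a carbonyl carbon. The step that bears on this change is a 10-fold higher number from compound 1 to compound 2 (1.00 log units; beyond the scatter), where 4-carboxyphenyl enters on a double-bonded chain carbon instead. The other step, an at least 100-fold higher number from compound 1 to compound 3 (2.00 log units; beyond the scatter), concerns bromo in place of methyl on an aromatic carbon and does not bear on it. A modest rise of similar size is therefore expected in this assay, the estimated step being an 8.0-fold higher number from compound 1 to compound 4 (0.90 log units; beyond the scatter). For compound 4 the expected value is 8000 nM, within an estimated range of 1500 nM to 50000 nM.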

Compound 4, concentration for 50% growth inhibition: 1000 nM
Compound 4: the middle estimate sits 8.0-fold (0.90 log units) above what was measured; the whole stated range lies above it.
By their numbers in this assay, from the lowest: compounds 1 and 4 (each within the scatter of the next); then compound 2. At a limit, above all of these: compound 3.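

In this assay, 4-carboxyphenyl is tolerated on the carbonyl carbon in place of 4-chloro-3-nitrophenyl, giving no change at the digits printed from compound 1 to compound 4 (within the scatter). The same group entering on the double-bonded chain carbon gave a 10-fold higher number from compound 1 to compound 2 (1.00 log units; beyond the scatter), so the rise seen at that place does not carry over to the carbonyl carbon. Nothing measured here accounts for this difference between the two places. On these data alone, whether a methyl ester or an amine in place of the carboxylic acid on this ring would give a similar value remains open.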